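The source may hold more compounds than are shown below. What is called first, only, known or untested is meant among the compounds shown, and "the series" means these compounds.

Compound 1, `CC[C@H](C)[C@@H](NC(=O)Cn1cc(C2=C(c3c[nH]c4ccccc34)C(=O)N(C)C2=O)c2ccccc21)C(=O)OC`, gives > 100000 nM in a functional assay on Bel-7402 cells (Homo sapiens) for cytotoxicity, read by MTT assay, with a stated time of 24 h (on this read-out lower numbers stand for stronger inhibition and higher numbers for weaker inhibition), which is a limit of the assay and not a number.
Compound 2, `COC(=O)[C@H](NC(=O)Cn1cc(C2=C(c3c[nH]c4ccccc34)C(=O)N(C)C2=O)c2ccccc21)[C@@H](C)O`, gives > 100000 nM in this assay, again a limit rather than a number.
Compound 3, `COC(=O)[C@H](NC(=O)Cn1cc(C2=C(c3c[nH]c4ccccc34)C(=O)N(C)C2=O)c2ccccc21)C(C)C`, gives 4010 nM in this assay.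

Compound 2 therefore stands among the weakest of the three: its value is only a limit, and it shares that position with compound 1, since (the limit of > 100000 nM in this assay, at which 2 of the 3 values shown sit). Within the data shown here, the one readable step leading away from compound 2 is an at least 24-fold lower number from compound 2 to compound 3 (1.39 log units; beyond the scatter), and the step of an at least 24-fold lower number from compound 1 to compound 3 (1.39 log units; beyond the scatter) points the same way, while a step that the two limits leave unreadable from compound 1 to compound 2 cannot be sized.

Compound 4, `COC(=O)[C@@H](CO)NC(=O)Cn1cc(C2=C(c3c[nH]c4ccccc34)C(=O)N(C)C2=O)c2ccccc21`, is not yet measured. It differs from compound 2 by hydrogen in place of methyl on a saturated chain carbon bound to an oxygen on a saturated carbon and a saturated chain carbon. Among the measured compounds shown here, none of the measured steps is this change: the hydroxy group that compound 2 and compound 4 share is kept, and only a methyl is lost. The gain seen in an at least 24-fold lower number from compound 2 to compound 3 (1.39 log units; beyond the scatter) came with the loss of the hydroxy altogether, which compound 4 does not do. He therefore expects no step beyond the scatter in this assay and expects the measurement of compound 4 to return a limit once more. His estimate for compound 4 is 100000 nM, within 30000 nM to 300000 nM, which is expected to mean a step of a number no higher from compound 2 to compound 4 (the limit leaves the size open).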

Compound 4, half-maximal inhibitory concentration: 67200 nM
Compound 4: middle estimate off by 1.5-fold (0.17 log units), on the high side; the measured number falls inside the stated range.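

With the hydroxy group kept, going from 1-hydroxyethyl to hydroxymethyl brings a readable number into this assay, but the step is only an at least 1.4-fold lower number from compound 2 to compound 4 (0.17 log units; that floor lies within the scatter), so no real gain is shown. Measured against the isopropyl chain, the hydroxymethyl chain reads as a 17-fold higher number from compound 3 to compound 4 (1.22 log units; beyond the scatter), which leaves compound 3 clearly the strongest of the four, while the comparison with the sec-butyl chain gives only an at least 1.4-fold lower number from compound 1 to compound 4 (0.17 log units; that floor lies within the scatter) and leaves the true size open. Losing a methyl at this chain carbon therefore need not carry the same size on both cores, although the limits keep that question unsettled: the same change on two cores in this assay, an at least 24-fold lower number (1.39 log units; beyond the scatter) from compound 1 to compound 3 and an at least 1.4-fold lower number (0.17 log units; that floor lies within the scatter) from compound 2 to compound 4; the limit leaves it open whether they differ.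

As far as these compounds go, the step between compound 1 and compound 2 still cannot be read, so how these two stand against each other stays unknown. The compounds shown also leave open how an amine or a carboxylic acid on this saturated chain carbon, or a longer chain there, would read in this assay.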